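Working notes: sulfonyl chain lengthening and cytotoxicity

The source may hold more compounds than are shown below. What is called first, only, known or untested is meant among the compounds shown, and "the series" means these compounds.

Compound 1 `CS(=O)(=O)N1CCC2(CC1)OOC1(CCCCCC1)OO2` carries a methylsulfonyl group; compound 3 `CCS(=O)(=O)N1CCC2(CC1)OOC1(CCCCCC1)OO2` carries an ethylsulfonyl group on the same core, the change being (methyl in place of hydrogen on a saturated chain carbon bound to a sulfonyl sulfur). In a functional assay on Huh-7 cells (Homo sapiens) for cytotoxicity, read by MTT assay, with a stated time of 72 h (on this read-out lower numbers stand for higher toxicity in this test and higher numbers for lower toxicity in this test), compound 1 gives > 100 ug/mL, which is a limit of the assay. In this assay compound 3 gives > 100 ug/mL, also a limit. The step that the two limits leave unreadable from compound 1 to compound 3 cannot be sized, since both values sit at the limit of > 100 ug/mL in this assay, at which 3 of the 3 values shown sit.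

Compound 2 `CCS(=O)(=O)N1CCC2(CC1)OOC1(CCCC1)OO2` has a different core from compound 1; the difference between the two cores is not broken down here. In this assay compound 2 gives > 100 ug/mL, again a limit. Compound 4 `CCCS(=O)(=O)N1CCC2(CC1)OOC1(CCCC1)OO2` is not yet measured; it differs from compound 2 by methyl in place of hydrogen on a saturated chain carbon, two bonds along the chain from a sulfonyl sulfur. This is the same kind of change as from compound 1 to compound 3, not the same: there the methyl enters on a saturated chain carbon bound to a sulfonyl sulfur, here on a saturated chain carbon two bonds along the chain from a sulfonyl sulfur.

The one measured case of this change sits at the limit of > 100 ug/mL in this assay, at which 3 of the 3 values shown sit, so the step from compound 2 to compound 4 is expected to be a step that the limit leaves unreadable from compound 2 to compound 4, unreadable in the same way. Compound 4 is accordingly expected to give 150 ug/mL in this assay, most likely reported again as a limit.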

Compound 4, half-maximal cytotoxic concentration: > 100 ug/mL
Compound 4: only a limit was reported; the forecaster's own chance of this, stated with the estimate: 85%; the middle value lies beyond the limit too.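

In this assay compound 4 gives > 100 ug/mL, a limit of the assay. No step can be read from compound 2 to compound 4, since both compounds sit at the same limit: the limit of > 100 ug/mL in this assay, at which 4 of the 4 values shown sit.

The compounds shown leave open where their true values lie past that limit, and whether lengthening the sulfonyl chain changes the read-out at all.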